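The source may report more compounds than this note shows. Statements on the series, on what has been measured and on what is new or still open speak of the compounds shown alone.

Measured in a functional assay on A549 cells (Homo sapiens) for cytotoxicity, read by MTT assay, with a stated time of 72 h; on this read-out lower numbers stand for stronger inhibition and higher numbers for weaker inhibition:
compound 1 `COc1ccc(Nc2nc3ccccc3nc2S(=O)(=O)c2ccc(OC)cc2)cc1` gives 8260 nM
compound 2 `COc1ccc(S(=O)(=O)c2nc3ccccc3nc2Nc2cc(OC)cc(OC)c2)cc1` gives 12700 nM
compound 3 `COc1ccc(S(=O)(=O)c2nc3ccccc3nc2Nc2ccc(F)cc2)cc1` gives 1240 nM

Compound 2 carries the highest number of the three in this assay. Its nearest neighbour is compound 1, with a 1.5-fold higher number from compound 1 to compound 2 (0.19 log units; within the scatter), a gap within the scatter; the furthest is compound 3, with a 10-fold lower number from compound 2 to compound 3 (1.01 log units; beyond the scatter). Within the data shown here, the only step that swaps a single group on an aromatic carbon rather than the whole aryl on the nitrogen is a 6.7-fold lower number from compound 1 to compound 3 (0.82 log units; beyond the scatter), and that swap sits on the aryl on the nitrogen.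

Compound 4 `COc1cc(Nc2nc3ccccc3nc2S(=O)(=O)c2ccc(Br)cc2)cc(OC)c1` keeps the 3,5-dimethoxyphenyl on the nitrogen of compound 2 and differs only in bromo in place of methoxy on an aromatic carbon, on the other aromatic ring, para to a large group. Among the measured compounds shown here, no measured step touches that ring, so nothing measured bears on this change directly. As far as these compounds go, the replacement of methoxy by a halogen on the aryl on the nitrogen gave a 6.7-fold lower number from compound 1 to compound 3 (0.82 log units; beyond the scatter); whether bromo on the other ring behaves alike is unknown. For compound 4 the expectation in this assay is a small step down, a 1.8-fold lower number from compound 2 to compound 4 (0.26 log units; within the scatter), which may well stay within the scatter. The estimate for compound 4 is 7000 nM, with a range of 2000 nM to 25000 nM.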

Compound 4, half-maximal inhibitory concentration: 15900 nM
The estimate for compound 4 lay 2.3-fold (0.36 log units) below the measured number, within the range that was stated.
By their numbers in this assay, from the lowest: compound 3; then compounds 1, 2 and 4 (each within the scatter of the next).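

In this assay, the change from 4-methoxyphenyl to 4-bromophenyl gives a 1.3-fold higher number from compound 2 to compound 4 (0.10 log units; within the scatter). With the 3,5-dimethoxyphenyl group held fixed, this position therefore shows no response to bromo in place of methoxy that stands clear of the scatter. Among these compounds, the one sizeable step so far for a halogen in place of methoxy, a 6.7-fold lower number from compound 1 to compound 3 (0.82 log units; beyond the scatter), comes from fluoro in a different aryl group, and nothing like it appears for this change at this position; no available evidence bears on why the two swaps read differently.

Among the compounds shown here, only one swap can be read at this position, and only alongside the 3,5-dimethoxyphenyl group, so it remains open whether the 4-bromophenyl group would read the same alongside the 4-fluorophenyl group of compound 3. Also open, as far as these compounds go, is how this place, para to a large group, would answer to a group of another kind, such as an amine or a carboxylic acid, in place of bromo or methoxy.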